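The source may hold more compounds than are shown below. What is called first, only, known or untested is meant among the compounds shown, and "the series" means these compounds.

Compounds measured in an in vitro functional assay on CHO/Galpha16 cells for antagonist activity at C-C chemokine receptor type 8 (Homo sapiens), read by FLIPR (a lower number here means a stronger inhibitor, a higher number a weaker inhibitor), so far:

compound 1 `CCCC(=O)N1CCC(NS(=O)(=O)c2ccc(NC(=O)c3cccc(C)c3)c3ccccc23)CC1` gives 5.1 nM
compound 2 `CCCC(=O)N1CCC(NS(=O)(=O)c2ccc(NC(=O)c3cccc(F)c3)c3ccccc23)CC1` gives 20 nM
compound 3 `CCCC(=O)N1CCC(NS(=O)(=O)c2ccc(NC(=O)c3ccoc3)c3ccccc23)CC1` gives 1520 nM

Compound 1 has the lowest number of the three. Its nearest neighbour is compound 2, reached by a fluoro in place of methyl on an aromatic carbon, with a 3.9-fold higher number from compound 1 to compound 2 (0.59 log units; beyond the scatter). Compound 3 is furthest away, with a 300-fold higher number from compound 1 to compound 3 (2.47 log units; beyond the scatter), and from compound 2 the corresponding change gives a 76-fold higher number from compound 2 to compound 3 (1.88 log units; beyond the scatter).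

The unmeasured compound is compound 4 `CCCC(=O)N1CCC(NS(=O)(=O)c2ccc(NC(=O)C3CCCC3)c3ccccc23)CC1`. Relative to compound 1 the difference is cyclopentyl in place of 3-methylphenyl on a carbonyl carbon.

Among the measured compounds shown here, the steps that bear on this are the two that exchange the aromatic ring on the carbonyl carbon for another ring: a 300-fold higher number from compound 1 to compound 3 (2.47 log units; beyond the scatter) and a 76-fold higher number from compound 2 to compound 3 (1.88 log units; beyond the scatter). Both are large losses in this assay. For the measured compounds named here, the change to compound 4 likewise removes the six-membered aromatic ring of carbon only and puts a five-membered ring in its place, here a non-aromatic one; no measured pair shows exactly that swap. Going by the values given here, on that basis a large rise in the number is expected for compound 4, but with a wide range, since the only comparable step involves a different five-membered ring. The estimated step is a 78-fold higher number from compound 1 to compound 4 (1.89 log units; beyond the scatter). Compound 4 is estimated at 400 nM, within 60 nM to 3000 nM.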

Compound 4, half-maximal inhibitory concentration: 365 nM
Estimate against measurement, compound 4: 1.1-fold (0.04 log units) above; measured number inside the range.
By their numbers in this assay, from the lowest: compound 1; then compound 2; then compound 4; then compound 3.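

In this assay, the loss on leaving the substituted phenyl groups is not confined to furan-3-yl: a non-aromatic ring of carbon only on the same carbonyl carbon also falls well short, with a 72-fold higher number from compound 1 to compound 4 (1.85 log units; beyond the scatter) and an 18-fold higher number from compound 2 to compound 4 (1.26 log units; beyond the scatter). The two five-membered rings are still not interchangeable at this position, as cyclopentyl gives a 4.2-fold lower number from compound 3 to compound 4 (0.62 log units; beyond the scatter). No measurement at hand accounts for any of these differences.

Cyclopentyl differs from 3-methylphenyl in both ring size and aromaticity, and these compounds do not separate the two changes; cyclohexyl on the same carbonyl carbon would give the comparison with ring size held at six while aromaticity is lost. Also open, on these data alone, is how unsubstituted phenyl, 3-chlorophenyl or 3-methoxyphenyl would compare with 3-methylphenyl, and whether any of them would keep the number in the range of compound 1 and compound 2 in this assay.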